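The source may report more compounds than this note shows. Statements on the series, on what has been measured and on what is new or still open speak of the compounds shown alone.

Compound 1 `Nc1ccc2oc(-c3ccc(C(F)(F)F)cc3)cc(=O)c2c1`: 273000 nM
Compound 2 `COc1ccc(-c2oc3ccc(N)cc3c(=O)c2O)cc1`: 239000 nM
Compound 3 `Nc1ccc2oc(-c3ccc(C(F)(F)F)cc3)c(O)c(=O)c2c1`: not yet measured

In an ADME assay on MT4 cells (Homo sapiens) for cytotoxicity, read by MTT assay, with a stated time of 4 days (on this read-out lower numbers stand for higher toxicity in this test and higher numbers for lower toxicity in this test), compound 2 gives 239000 nM, level within the scatter with compound 1 at 273000 nM. Compound 3 follows from compound 2 with trifluoromethyl in place of methoxy on an aromatic carbon, para to a large group: trifluoromethyl in place of methoxy on an aromatic carbon. Among the compounds with values here, no measured pair isolates this change, and both measured values sit close together, so no shift beyond the scatter is expected. The estimated move is a 1.1-fold lower number from compound 2 to compound 3 (0.04 log units; within the scatter). For compound 3 the expected value is 220000 nM, with an estimated range of 80000 nM to 400000 nM.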

Compound 3, half-maximal cytotoxic concentration: 3900 nM
Beside the measured number, compound 3's estimate is 56-fold (1.75 log units) above it, and the stated range ends above it.
By their numbers in this assay, from the lowest: compound 3; then compounds 2 and 1 (each within the scatter of the next).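

In this assay, trifluoromethyl in place of methoxy on an aromatic carbon, para to a large group, carries a large step when the hydroxy is present (a 61-fold lower number from compound 2 to compound 3 (1.79 log units; beyond the scatter)). Hydroxy in place of hydrogen on an aromatic carbon carries a step of similar size when the trifluoromethyl is present (a 70-fold lower number from compound 1 to compound 3 (1.85 log units; beyond the scatter)), so the low number appears only with both groups together among these compounds. Nothing at hand gives a cause for either step.

From the compounds shown here alone, whether methoxy without the hydroxy gives a comparable number remains open. So does whether a nitrile or a chlorine in the trifluoromethyl place, or an amine in the hydroxy place, would keep the lower number.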